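Swapping one aromatic group and expecting a small shift

This account rests on a few compounds, and the source may have more. Where it says the series, first, only, none or still open, it means among the compounds named here.

Of the compounds shown here, three have been tested in an in vitro ADME assay on microsomes from liver (Rattus norvegicus) for metabolic stability; a lower number here means slower removal, a higher number faster removal of the compound: compound 1 `CN1C(=O)C(C)(C)C[C@H]1C(=O)NCc1cccc(C(F)(F)F)c1Cl`, compound 2 `CN1C(=O)COC[C@H]1C(=O)NCc1cccc(C(F)(F)F)c1Cl` and compound 3 `Cc1ncccc1N1C[C@@H](C(=O)NCc2cccc(C(F)(F)F)c2Cl)N(C)C1=O`. Compound 1 gives < 0.5 mL.min-1.g-1, which is a limit of the assay and not a number. Compound 2 gives < 0.5 mL.min-1.g-1, which is also a limit. For the measured compounds named here, compound 3 gives 2.6 mL.min-1.g-1, the only actual number among the three, and it is the starting point here.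

Compound 4 `CN1C(=O)N(c2cn(C)cn2)C[C@H]1C(=O)NCc1cccc(C(F)(F)F)c1Cl` has not yet been measured in this assay. It differs from compound 3 in one place 1-methyl-1H-imidazol-4-yl in place of 2-methylpyridin-3-yl on an amide-type nitrogen in a ring: 1-methyl-1H-imidazol-4-yl stands in place of 2-methylpyridin-3-yl on an amide-type nitrogen in a ring. Both groups are aromatic rings with no net charge.

Going by the values given here, no two measured compounds differ in just one place, so the effect of a swap like this has not been observed directly. A small downward step from compound 3 at 2.6 mL.min-1.g-1 seems the most reasonable expectation, one that does not clearly leave the usual scatter. The expected change is a 1.6-fold lower number from compound 3 to compound 4 (0.21 log units; within the scatter). For compound 4 the estimated value is 1.6 mL.min-1.g-1, with an expected range from 0.6 mL.min-1.g-1 to 4 mL.min-1.g-1.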

Compound 4, intrinsic clearance in microsomes: < 0.5 mL.min-1.g-1
Compound 4: no number, only a limit; the forecaster's own chance of this, stated with the estimate: 15%; middle value at least 3.2-fold (0.50 log units) from the limit.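

In this assay, for the compounds shown here, placing 1-methyl-1H-imidazol-4-yl instead of 2-methylpyridin-3-yl on the amide-type nitrogen gives an at least 5.2-fold lower number from compound 3 to compound 4 (0.71 log units; beyond the scatter), the first change at a single place that can be read in this set of compounds. This shows that the number is sensitive to which aromatic ring sits at this position, even though both rings carry no net charge and differ by only a small count of atoms. Compound 4 gives only a limit of the assay and not a number, so the step sets a lower bound on the change and its full size stays unknown: the limit of < 0.5 mL.min-1.g-1 in this assay, at which 3 of the 4 values shown sit.

The swap changes ring size, the count of hetero atoms and the methyl group all at once, so this single step cannot show which of these differences goes with the lower number. A plain phenyl ring or a pyridin-3-yl ring without the methyl group at the same place would help separate them, although any compound that reached the same limit as compound 4 could not be ranked against it.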